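The compounds below may be only part of what the source reports. "The series", "measured", "known", "first", "only" and "open" are said of these compounds alone.

Two ureas on a shared core have been measured. Among the compounds with values here, in an assay on isolated protein for inhibition of serine/threonine-protein kinase 10 (Homo sapiens), read by thermal shift assay, tested at 10 uM (a lower number here means that the compound stabilises the target less, a higher number that the compound stabilises the target more against heat), compound 1 `CC(C)(C)c1cc(NC(=O)Nc2cc(C(F)(F)F)cc(C(F)(F)F)c2)n(-c2ccccc2)n1` gives -0.5 degrees C, and compound 2 `Cn1nc(C(C)(C)C)cc1NC(=O)Nc1cc(C(F)(F)F)cc(C(F)(F)F)c1` gives 1.1 degrees C. The only measured step, a number 1.6 degrees C higher from compound 1 to compound 2 (beyond the scatter), leaves compound 2 standing highest of the two numbers, with compound 1 the nearest and lower by that step. Compound 3 `CC(C)(C)c1cc(NC(=O)Nc2cc(C(F)(F)F)cc(C(F)(F)F)c2)n(-c2ccc(F)cc2)n1` differs from compound 2 by 4-fluorophenyl in place of methyl on an aromatic nitrogen. This largely runs the measured step backwards, so a drop of similar size is expected in this assay. Compound 3 is estimated at -0.4 degrees C, within -1.5 degrees C to 0.7 degrees C. That estimate means an expected step of a number 1.5 degrees C lower from compound 2 to compound 3 (beyond the scatter).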

Compound 3, shift of the target's melting temperature: -0.6 degrees C
Beside the measured number, compound 3's estimate is 0.20 degrees C above it, within the range that was stated.
By their numbers in this assay, from the lowest: compounds 3 and 1 (each within the scatter of the next); then compound 2.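

In this assay, the step of a number 1.7 degrees C lower from compound 2 to compound 3 (beyond the scatter) shows that a second aryl group on this aromatic nitrogen also stands apart from methyl. Fluoro in place of hydrogen on an aromatic carbon gives a number 0.10 degrees C lower from compound 1 to compound 3 (within the scatter) and so leaves the number for the phenyl group unmoved within the scatter. Nothing available bears on the reason for these results. On these data alone, whether the ring itself or only the larger group sets the lower numbers stays open. Ethyl, cyclohexyl or a 4-aminophenyl group on this nitrogen would test how far this reading holds.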